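This account rests on a few compounds, and the source may have more. Where it says the series, first, only, none or still open, it means among the compounds named here.

Working notes on the series, read in a functional assay on HCT-116 cells (Homo sapiens) for inhibition, read by sulforhodamine B assay, with a stated time of 48 h, tested at 50 uM; on this read-out higher numbers stand for more inhibition of growth at the one concentration tested and lower numbers for less inhibition of growth. Compound 1 (`COc1cccc(/C=C/C(=O)/C=C/c2ccc(OCc3cn(CCCCCOc4cc(=O)oc5ccccc45)nn3)c(OC)c2)c1`) gives 36% and compound 2 (`COc1cc(/C=C/C(=O)/C=C/c2ccccc2)ccc1OCc1cn(CCCCCOc2cc(=O)oc3ccccc23)nn1`) gives 24%, which leaves compound 2 as the lower of the two measured compounds. Compound 3 (`COc1cc(/C=C/C(=O)/C=C/c2cc(OC)c(OC)c(OC)c2)ccc1OCc1cn(CCCCCOc2cc(=O)oc3ccccc23)nn1`) departs from compound 2 on a double-bonded chain carbon bound to a double-bonded chain carbon: 3,4,5-trimethoxyphenyl in place of phenyl on a double-bonded chain carbon bound to a double-bonded chain carbon. Within the data shown here, one measured step bears on this change: a number 12 percentage points lower from compound 1 to compound 2 (beyond the scatter), modest and beyond the scatter, with hydrogen in place of methoxy on an aromatic carbon. The new change runs the other way, bringing methoxy groups in rather than taking one out, so a rise of similar or somewhat larger size is expected, though a single step is thin support. The expected move is a number 14 percentage points higher from compound 2 to compound 3 (beyond the scatter). For compound 3 the estimate is 38%, with an expected range of 22% to 55%.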

Compound 3, percent growth inhibition at one concentration: 53%
Estimate against measurement, compound 3: 15 percentage points below; measured number inside the range.
By their numbers in this assay, from the lowest: compound 2; then compound 1; then compound 3.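

In this assay, 3,4,5-trimethoxyphenyl in place of phenyl on a double-bonded chain carbon bound to a double-bonded chain carbon gives a number 29 percentage points higher from compound 2 to compound 3 (beyond the scatter), a larger step at this position than the earlier pair showed. Against 3-methoxyphenyl the same group still gives a number 17 percentage points higher from compound 1 to compound 3 (beyond the scatter), so the order at this position runs phenyl, then 3-methoxyphenyl, then 3,4,5-trimethoxyphenyl, and none of these compounds goes against it. No measured evidence accounts for this rise.

From the compounds shown here alone, whether a hydroxy group, a fluorine or an amine on the same ring would match the methoxy groups stays open. Also open, going by these compounds, is whether this order would hold at other concentrations, as the read-out covers a single concentration.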